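The source may hold more compounds than are shown below. What is called first, only, known or untested is meant among the compounds shown, and "the series" means these compounds.

Working notes on the series. For the measured compounds named here, in a functional assay on HeLa cells (Homo sapiens) for inhibition, read by MTT assay, with a stated time of 48 h (on this read-out lower numbers stand for stronger inhibition and higher numbers for weaker inhibition), compound 1 (`CCOC(=O)C1=C(N/N=C(\C#N)C(N)=O)Nc2[nH]nc(C)c2C1c1ccc(N(C)C)cc1`) gives 47300 nM, the higher of the two numbers so far and so the weaker inhibition. Compound 2 (`CCOC(=O)C1=C(N/C=N/c2ncc(-c3ccccc3)s2)Nc2[nH]nc(C)c2C1c1ccc(N(C)C)cc1`) gives 15400 nM, a lower number by more than the usual scatter. Compound 3 (`CCOC(=O)C1=C(N/N=C(/Br)c2ccccc2)Nc2[nH]nc(C)c2C1c1ccc(N(C)C)cc1`) has not yet been measured. It departs from compound 1 by a group of 9 heavy atoms (7 carbon, 1 nitrogen, 1 bromine; one six-membered aromatic ring of carbon only) in place of a group of 7 heavy atoms (3 carbon, 3 nitrogen, 1 oxygen; no ring), on an amine nitrogen: a group with one six-membered aromatic ring of carbon only, and with bromine, in place of a group with no ring, on an amine nitrogen. Going by the values given here, no pair of measured compounds differing in one place exists, so the data give no direct guide to this change. A modest fall in the number is expected in this assay, possibly not much beyond the scatter. This expectation rests only on compound 2 at 15400 nM, whose group also holds a six-membered aromatic ring of carbon only. The expected change is a 2.4-fold lower number from compound 1 to compound 3 (0.37 log units; beyond the scatter). The estimate for compound 3 is 20000 nM, with an expected range from 7000 nM to 50000 nM.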

Compound 3, half-maximal inhibitory concentration: 75700 nM
The estimate for compound 3 lay 3.8-fold (0.58 log units) below the measured number; measured number outside the range, above it.
By their numbers in this assay, from the lowest: compound 2; then compounds 1 and 3 (each within the scatter of the next).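

In this assay, the change on the amine nitrogen is a 1.6-fold higher number from compound 1 to compound 3 (0.20 log units; within the scatter), so at this position a group with no ring and a hydrogen-bond donor gives way to one with a six-membered aromatic ring of carbon only, bromine and no hydrogen-bond donor, while the number stays within the scatter. A six-membered aromatic ring of carbon only in the group on this nitrogen therefore does not by itself go with a lower number, something compound 2 alone could not show. No measurement at hand explains this outcome.

The ring and the bromine enter together in compound 3, so the compounds shown do not separate them, and it remains open how the number would respond to chlorine or an amine in place of the bromine while the ring stays. Also open is which part of the group in compound 2 goes with its 15400 nM, as no compound shown carries only a portion of that group on this nitrogen.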